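The compounds below may be only part of what the source reports. "The series", "measured", "known", "first", "only" and "open" are said of these compounds alone.

Series notes. Compound 1, `O=C(O)CNC(=O)[C@]1(O)C[C@@H](O)[C@@H](O)[C@H](O)C1`, and compound 2, `C[C@H](NC(=O)[C@]1(O)C[C@@H](O)[C@@H](O)[C@H](O)C1)C(=O)O`, share one core and differ only at the amide-bearing side chain. In an assay on HL-60 cells for inhibition of P-selectin (Homo sapiens) (on this read-out lower numbers stand for stronger inhibition and higher numbers for weaker inhibition), compound 1 gives only the assay limit of > 50000000 nM. In this assay compound 2 likewise reaches only the limit, > 50000000 nM. The step that the two limits leave unreadable from compound 1 to compound 2 is therefore unreadable, since both of its ends sit at the limit of > 50000000 nM in this assay, at which 2 of the 2 values shown sit. Compound 2 thus stands at the limit of this assay, with no number beneath it.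

Compound 3, `CCC(C)[C@H](NC(=O)[C@]1(O)C[C@@H](O)[C@@H](O)[C@H](O)C1)C(=O)O`, differs from compound 2 by sec-butyl in place of methyl on a saturated chain carbon bound to an amide-type nitrogen and a carbonyl carbon. Of the measured steps only a step that the two limits leave unreadable from compound 1 to compound 2 bears on the same place, and its size cannot be read because both of its values rest at the limit of > 50000000 nM in this assay, at which 2 of the 2 values shown sit. Going by the values given here, no measured step gives a direction or a size for this assay here. Compound 3 is therefore expected to remain at the limit as well, so the expected step of a number no higher from compound 2 to compound 3 (the limit leaves the size open) is itself not readable. The estimate for compound 3 in this assay is 50000000 nM, within 5000000 nM to 500000000 nM, most likely reported again only as a limit.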

Compound 3, half-maximal inhibitory concentration: 19000000 nM
Estimate against measurement, compound 3: 2.6-fold (0.42 log units) above, and the stated range covers the measured number.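

On a saturated chain carbon bound to an amide-type nitrogen and a carbonyl carbon, sec-butyl in place of methyl gives an at least 2.6-fold lower number from compound 2 to compound 3 (0.42 log units; beyond the scatter) in this assay and turns this place from one that only reached the limit into one with a readable number. Taken from the hydrogen on the same carbon, the change to sec-butyl shows an at least 2.6-fold lower number from compound 1 to compound 3 (0.42 log units; beyond the scatter) and, as in the step from methyl, the true size may be larger, since the starting compound rests at a limit. The step from hydrogen to methyl cannot be read, so this position offers a direction for sec-butyl but no trend with chain size, and the number for compound 3 stands alone: the limit of > 50000000 nM in this assay, at which 2 of the 3 values shown sit.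

As far as these compounds go, whether this drop in the number belongs to sec-butyl in particular, or would also appear with a longer straight chain, a phenyl ring or an amine on the same carbon, stays open. Also open, from the compounds shown here alone, is how far the number depends on the carboxylic acid of the side chain, which all three compounds carry, and whether an ester or a primary amide there would keep it.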